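Working Notes: Methoxy for Hydrogen, Compound 2 to Compound 3

This account rests on a few compounds, and the source may have more. Where it says the series, first, only, none or still open, it means among the compounds named here.

Measured so far:
compound 1 `O=C(OCCCc1ccccc1)c1cc(-n2cc(-c3cccc(O)c3)nn2)ccc1O`: 11%
compound 2 `COc1ccccc1-c1cn(-c2ccc(O)c(C(=O)OCCCc3ccccc3)c2)nn1`: 7%

In a functional assay on HCT-116 cells (Homo sapiens) for inhibition, read by MTT assay, with a stated time of 2 days, tested at 10 uM (on this read-out lower numbers stand for less inhibition and higher numbers for more inhibition at the one concentration tested (going by the name of the read-out)), compound 1 gives 11% and compound 2 gives 7%. The number for compound 2 is the smaller of the two, yet the step of a number 4 percentage points lower from compound 1 to compound 2 (within the scatter) lies within the scatter, so no order between the two can be claimed; both sit at a low level of inhibition.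

Compound 3 `COc1ccc(OC)c(-c2cn(-c3ccc(O)c(C(=O)OCCCc4ccccc4)c3)nn2)c1` differs from compound 2 by methoxy in place of hydrogen on an aromatic carbon. For the measured compounds named here, the only measured step that bears on this position is the one from compound 1 to compound 2, which also reworked the same ring and stayed within the scatter, a number 4 percentage points lower from compound 1 to compound 2 (within the scatter). A change of one methoxy on that ring therefore gives no ground to expect movement beyond the scatter in this assay.

For compound 3 the expected value is 9% (range 0% to 22%). The step implied by this estimate, a number 2 percentage points higher from compound 2 to compound 3 (within the scatter), is expected to stay within the scatter.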

Compound 3, a percentage reported as inhibition, at one concentration (the size of the read-out at that concentration, not a potency): 13%
Compound 3: the middle estimate sits 4 percentage points below what was measured, within the range that was stated.
By their numbers in this assay, from the lowest: compounds 2, 1 and 3 (each within the scatter of the next).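

In this assay, methoxy in place of hydrogen on the aromatic carbon para to a methoxy group and meta to a large group gives a number 6 percentage points higher from compound 2 to compound 3 (within the scatter), so this added methoxy does not separate the two compounds. Against the 3-hydroxyphenyl group, the 2,5-dimethoxyphenyl group gives a number 2 percentage points higher from compound 1 to compound 3 (within the scatter), and none of the three groups tested at this position stands apart from the others in this assay. No evidence is available to explain these results.

As far as these compounds go, whether an amine, a carboxylic acid or a longer chain in place of the added methoxy would give a step beyond the scatter remains open. Also open, from the compounds shown here alone, is how changes elsewhere on the shared core would read in this assay for this series.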